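Replacing an amide-bearing ring with an aminopyridine

The compounds below may be only part of what the source reports. "The series", "measured", "known", "first", "only" and "open" are said of these compounds alone.

The three compounds here share one core and differ only in the group attached to the saturated chain carbon bound to a sulfonyl sulfur. Compound 1 `CC(C)c1cc(CS(=O)(=O)N2CCN(c3cnn(-c4cccc(Cl)c4)c(=O)c3OCC3(C)CC3)CC2)ccc1N` was tested in an in vivo ADME assay on the whole organism for pharmacokinetics, with Rattus norvegicus as the target, at a dose of 10 mg/kg by the oral route (on this read-out lower numbers stand for lower exposure and higher numbers for higher exposure at the dose given), and compound 1 gives 1190 nM. Compound 2 `CC1(COc2c(N3CCN(S(=O)(=O)Cc4ccc(N)c(C(N)=O)c4)CC3)cnn(-c3cccc(Cl)c3)c2=O)CC1` was submitted to the same study, but in this assay compound 2 gives "not determined" (no result reported), so there is no number on which compound 2 can be placed. Compound 3 `CC1(COc2c(N3CCN(S(=O)(=O)Cc4cccnc4N)CC3)cnn(-c3cccc(Cl)c3)c2=O)CC1` is the next member of the series and has not yet been measured in this assay. The change from compound 2 to compound 3 is 2-aminopyridin-3-yl in place of 4-amino-3-carbamoylphenyl on a saturated chain carbon bound to a sulfonyl sulfur. Going by the values given here, no measured pair in this set shows how such a change shifts the read-out, so the direction of the step in this assay cannot be read from the data; the expectation is a shift that stays within the usual scatter, with no clear direction. On that basis compound 3 is expected to give 1000 nM in this assay, with a likely range from 300 nM to 3500 nM.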

Compound 3, maximal plasma concentration: 3120 nM
Beside the measured number, compound 3's estimate is 3.1-fold (0.49 log units) below it; measured number inside the range.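

In this assay, going by these compounds alone, putting 2-aminopyridin-3-yl in place of 4-amino-3-isopropylphenyl on a saturated chain carbon bound to a sulfonyl sulfur gives a 2.6-fold higher number from compound 1 to compound 3 (0.42 log units; beyond the scatter), the first measured evidence that the read-out responds to this position while the rest of the molecule stays the same. It also shows that this position can carry a six-membered aromatic ring with one hetero atom, rather than one of carbon only, and still reach a higher number at the same oral dose, although the step from compound 2 to compound 3 cannot be read, as compound 2 has no number. Nothing measured here explains why the number rises between these two compounds.

On these data alone, with one readable step, it remains open whether the ring nitrogen, the loss of the isopropyl group or the different placement of the amine accounts for the change. A simple pyridin-3-yl without the amine, or a 4-aminophenyl without the isopropyl group, would help separate these parts of the change.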